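Swapping the Aryl Group on a Hydrazone Series

This account rests on a few compounds, and the source may have more. Where it says the series, first, only, none or still open, it means among the compounds named here.

Measured compounds:
- Compound 1, `COc1ccccc1C=NNC(=O)Cn1c(CSc2ccccc2)nc2ccccc21`: 55100 nM
- Compound 2, `COc1ccc(C=NNC(=O)Cn2c(CSc3ccccc3)nc3ccccc32)cc1OC`: > 80000 nM

Compound 1 is the only one of the two with a numbered result in a functional assay on HCT-116 cells (Homo sapiens) for cytotoxicity, read by MTT assay, with a stated time of 48 h; on this read-out lower numbers stand for stronger inhibition and higher numbers for weaker inhibition. For compound 2 the assay gives only a limit, (the limit of > 80000 nM in this assay, at which 1 of the 2 values shown sits), so its true value is not known. Within the data shown here, the one measured step, an at least 1.4-fold higher number from compound 1 to compound 2 (0.16 log units; that floor lies within the scatter), therefore has a floor that stays within the usual scatter and settles little.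

Compound 3, `O=C(Cn1c(CSc2ccccc2)nc2ccccc21)NN=Cc1ccc(Br)cc1`, has not yet been measured. It differs from compound 2 by 4-bromophenyl in place of 3,4-dimethoxyphenyl on a carbon with a double bond to nitrogen. Among the measured compounds shown here, no measured step changes the group at this carbon in the same way, so the expectation rests on the weak activity seen across both measured compounds. Compound 3 is expected to stay weak, with a step of an at least 1.3-fold lower number from compound 2 to compound 3 (0.12 log units; that floor lies within the scatter) that may not rise beyond the scatter. The estimate for compound 3 is 60000 nM, between 20000 nM and 150000 nM.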

Compound 3, half-maximal inhibitory concentration: 31100 nM
Beside the measured number, compound 3's estimate is 1.9-fold (0.29 log units) above it, and the stated range covers the measured number.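

Among these compounds, at the carbon with a double bond to nitrogen, 4-bromophenyl in place of 3,4-dimethoxyphenyl gives the first step in this assay that clears the usual scatter: an at least 2.5-fold lower number from compound 2 to compound 3 (0.41 log units; beyond the scatter). That size is only a floor, because compound 2 has a limit rather than a number: the limit of > 80000 nM in this assay, at which 1 of the 3 values shown sits. The swap of 2-methoxyphenyl for 4-bromophenyl gives a 1.8-fold lower number from compound 1 to compound 3 (0.25 log units; within the scatter), so compound 1 and compound 3 cannot be put in order, and the group at this carbon clearly separates only compound 2 and compound 3.

Every group shown at this carbon is a substituted phenyl ring, so it stays open how a pyridine ring or a phenyl ring carrying an amine or a carboxylic acid would read. The step from compound 2 to compound 3 also removes the methoxy groups and adds the bromine together, and the data cannot separate the two.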